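From oxan-4-yl to tert-butoxy: estimating compound 4

The source may hold more compounds than are shown below. What is called first, only, known or untested is meant among the compounds shown, and "the series" means these compounds.

- compound 1 `Cc1cc(C(=O)NCc2ccccc2)nn1Cc1cc(Cl)ccc1OCc1ccccc1`: 15 mL.min-1.g-1
- compound 2 `Cc1cc(C(=O)NCc2ccccn2)nn1Cc1cc(Cl)ccc1OCc1ccccc1`: 30 mL.min-1.g-1
- compound 3 `Cc1cc(NC(=O)C2CCOCC2)nn1Cc1cc(Cl)ccc1OCc1ccccc1`: 9.1 mL.min-1.g-1

In an in vitro ADME assay on microsomes from liver (Rattus norvegicus) for metabolic stability (on this read-out lower numbers stand for slow clearance and higher numbers for fast clearance), compound 3 gives 9.1 mL.min-1.g-1. Two steps place it among the measured numbers: a 1.6-fold lower number from compound 1 to compound 3 (0.22 log units; within the scatter), and a 3.3-fold lower number from compound 2 to compound 3 (0.52 log units; beyond the scatter). Compound 4 `Cc1cc(NC(=O)OC(C)(C)C)nn1Cc1cc(Cl)ccc1OCc1ccccc1` carries tert-butoxy in place of oxan-4-yl on a carbonyl carbon. Within the data shown here, no measured step makes this exact swap. The closest evidence is those same two steps, which replace a larger piece at the same part of the molecule, and even they stay small. A change beyond the scatter is therefore not expected in this assay. The expected step is a 1.4-fold higher number from compound 3 to compound 4 (0.15 log units; within the scatter). Compound 4 is estimated at 13 mL.min-1.g-1, with an expected range of 5 mL.min-1.g-1 to 32 mL.min-1.g-1.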

Compound 4, intrinsic clearance in microsomes: 2.2 mL.min-1.g-1
For compound 4 the middle estimate is 5.9-fold (0.77 log units) above the measured one, outside the stated range (below it).
By their numbers in this assay, from the lowest: compound 4; then compounds 3, 1 and 2 (each within the scatter of the next, the first and the last beyond it).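

In this assay, among these compounds, this position proves more sensitive than the earlier compounds suggested: tert-butoxy in place of oxan-4-yl on the carbonyl carbon gives a clear drop (a 4.1-fold lower number from compound 3 to compound 4 (0.62 log units; beyond the scatter)). The (tert-butoxycarbonyl)amino group also sets compound 4 well apart from the two amide compounds (a 6.8-fold lower number from compound 1 to compound 4 (0.83 log units; beyond the scatter); a 14-fold lower number from compound 2 to compound 4 (1.13 log units; beyond the scatter)), leaving compound 4 with the lowest number of the four.

Going by these compounds, whether methoxy or a longer chain on the same carbonyl carbon would give a similarly low number remains open. Nothing available here explains why the number falls with tert-butoxy.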